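The source may report more compounds than this note shows. Statements on the series, on what has been measured and on what is new or still open speak of the compounds shown alone.

Measured compounds:
compound 1 `CCOC(=O)/C=C/c1ccncc1-c1ccc2c(cnn2C)c1` gives 100%
compound 2 `COC1CN(C(=O)/C=C/c2ccncc2-c2ccc(F)cc2)C1` gives 77%

Both compounds were run in an assay on a protein complex for inhibition of CDK8/Cyclin C (Homo sapiens), with a stated time of 1 h, tested at 10 uM; on this read-out lower numbers stand for less inhibition and higher numbers for more inhibition at the one concentration tested (going by the name of the read-out). Compound 1 shows 100% in this assay, while compound 2 shows 77% in this assay. For the measured compounds named here, compound 2 thus holds the lower of the two numbers; its only neighbour, compound 1, sits higher by a margin that lies beyond the usual scatter of this read-out. Going by the values given here, no pair of measured compounds differing in a single place is available, so no measured step can be drawn on for the next change.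

The step to be followed goes from compound 2 to compound 3 `CN1CCN(C(=O)/C=C/c2ccncc2-c2ccc(F)cc2)CC1`, which has not yet been run in this assay. The change is 4-methylpiperazin-1-yl in place of 3-methoxyazetidin-1-yl on a carbonyl carbon. Both groups are amide partners on the same carbonyl carbon, and the rest of the structure is unchanged, so the change in this assay is expected to be small, with no step beyond the scatter anticipated in either direction, and a slight downward drift regarded as the more likely side. The expected shift is a number 7 percentage points lower from compound 2 to compound 3 (within the scatter). On that basis compound 3 is estimated at 70% in this assay, within a range from 45% to 90%.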

Compound 3, a percentage reported as inhibition, at one concentration (the size of the read-out at that concentration, not a potency): 84%
Beside the measured number, compound 3's estimate is 14 percentage points below it, and the stated range covers the measured number.
By their numbers in this assay, from the lowest: compounds 2 and 3 (each within the scatter of the next); then compound 1.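

On the carbonyl carbon whose other neighbour is the double-bonded chain carbon, the series now has its first single-place step in this assay: 4-methylpiperazin-1-yl in place of 3-methoxyazetidin-1-yl gives a number 7 percentage points higher from compound 2 to compound 3 (within the scatter). At this position, then, a four-membered non-aromatic ring with 1 hetero atom and a six-membered non-aromatic ring with 2 hetero atoms cannot be told apart by this read-out, with the rest of the structure unchanged and the donor and acceptor counts the same. No measurement at hand bears on the reason for this result.

On these data alone, whether this position stays as undemanding for an open-chain partner such as dimethylamino, or for a ring carrying a free amine such as piperazin-1-yl, remains open. As far as these compounds go, compound 1 differs from both amides in more than one place, so what the ethyl ester and the fused bicyclic group each contribute to this assay also remains open, and only a step changing one of them alone could separate the two.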